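Replacing the cyanomethyl amide of compound 2 with a Boc-hydrazide

The compounds below may be only part of what the source reports. "The series", "measured", "known", "first", "only" and "open" are said of these compounds alone.

Measured compounds:
compound 1 `CSc1nc(-c2cccc(O)c2)c2c(N)c(C(=O)NC(C)(C)C)sc2n1`, 63.9%
compound 2 `COc1cccc(-c2nc(SC)nc3sc(C(=O)NCC#N)c(N)c23)c1`, 20.3%
compound 3 `CSc1nc(-c2cccc(F)c2)c2c(N)c(C(=O)NC(C)(C)C)sc2n1`, 51.1%

In a functional assay on HEK293 cells for agonist activity at lutropin-choriogonadotropic hormone receptor (Homo sapiens), read by cAMP accumulation (a lower number here means a smaller maximal response, a higher number a larger maximal response), compound 2 stands lowest of the three, well beyond the scatter from compound 3 and further still from compound 1. Compound 4 `COc1cccc(-c2nc(SC)nc3sc(C(=O)NNC(=O)OC(C)(C)C)c(N)c23)c1` differs from compound 2 in one place: (tert-butoxycarbonyl)amino in place of cyanomethyl on an amide-type nitrogen. Among the compounds with values here, the only measured step, a number 12.8 percentage points lower from compound 1 to compound 3 (beyond the scatter), concerns the aromatic ring, not the amide nitrogen, so it does not bear directly on this change. Compounds 1 and 3, which carry a different amide substituent, both give higher values than compound 2, suggesting the amide substituent matters. A rise is therefore expected, though its size is uncertain. The expected step is a number 14.7 percentage points higher from compound 2 to compound 4 (beyond the scatter). Compound 4 is estimated at 35%, ranging from 10% to 65%.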

Compound 4, largest response reached (reported as efficacy), in percent of the reference or control that the assay uses: 2.4%
Beside the measured number, compound 4's estimate is 32.6 percentage points above it; measured number outside the range, below it.
By their numbers in this assay, from the lowest: compound 4; then compound 2; then compound 3; then compound 1.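

With (tert-butoxycarbonyl)amino in place of cyanomethyl on the amide-type nitrogen, this assay shows a number 17.9 percentage points lower from compound 2 to compound 4 (beyond the scatter). Within the data shown here, this is the first pair to isolate the amide substituent, showing that changing it alone, with the rest of the molecule held the same, can shift the maximal response. Nothing available explains why the response falls. Still open, from the compounds shown here alone, is whether a plain amino group on this nitrogen would give a similar response, which would separate the effect of the added nitrogen from that of the tert-butoxycarbonyl group. Going by these compounds, the same change with the hydroxy or fluoro aromatic ring also remains open.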